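The source may hold more compounds than are shown below. What is called first, only, known or untested is meant among the compounds shown, and "the series" means these compounds.

Working notes on the series. In an assay on isolated protein for binding affinity to Discoidin domain-containing receptor 2 (Homo sapiens), read by thermal shift assay, tested at 10 uM (a lower number here means that the compound stabilises the target less, a higher number that the compound stabilises the target more against heat), compound 1 `CCCNC(=O)[C@H](CCC1CCCCC1)NC(=O)c1ccc(CNC(=O)c2cnn(-c3ccccc3)c2N)cc1` gives 3.8 degrees C. Compound 2 `CS(=O)(=O)N1CCCC(NC(=O)[C@H](CCC2CCCCC2)NC(=O)c2ccc(CNC(=O)c3cc(-c4ccccc4)n[nH]3)cc2)C1` gives 2 degrees C in this assay, the lower of the two numbers, with compound 1 standing higher by a gap beyond the scatter. Compound 3 `CC(NC(=O)c1cc(-c2ccccc2)n[nH]1)c1ccc(C(=O)N[C@@H](CCC2CCCCC2)C(=O)NC2CCCN(S(C)(=O)=O)C2)cc1` differs from compound 2 by methyl in place of hydrogen on a saturated chain carbon bound to an amide-type nitrogen and an aromatic carbon. For the measured compounds named here, no step between measured compounds is available to gauge such a change; the expected step of a number 0.20 degrees C higher from compound 2 to compound 3 (within the scatter) is small, in no clear direction, and not beyond the scatter. For compound 3 the estimate is 2.2 degrees C, with a range from 1 degrees C to 3.5 degrees C.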

Compound 3, shift of the target's melting temperature: 1.7 degrees C
Beside the measured number, compound 3's estimate is 0.50 degrees C above it; low and high end bracket the measured number.
By their numbers in this assay, from the lowest: compounds 3 and 2 (each within the scatter of the next); then compound 1.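

In this assay, for the compounds shown here, the step of a number 0.30 degrees C lower from compound 2 to compound 3 (within the scatter) is the first reading of methyl in place of hydrogen at this position, on a saturated chain carbon bound to an amide-type nitrogen and an aromatic carbon. The position takes the added methyl with no change beyond the scatter. No supporting evidence bears on this result. From the compounds shown here alone, whether ethyl, a hydroxymethyl group or a primary amine on this carbon would also stay within the scatter remains open.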